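Swapping the distal aryl substituent in a nitroaryl carbinol series

The compounds below may be only part of what the source reports. "The series", "measured", "known", "first", "only" and "open" are said of these compounds alone.

Three compounds share a dimethoxy-nitrophenyl carbinol core and differ only in the outer aryl ring. Compound 1 `COc1cc(CC(O)c2ccc(-c3ccc(C)cc3)cc2)c([N+](=O)[O-])cc1OC` gives 4700 nM in an ADME assay on HeLa Rh cells (Homo sapiens) for cytotoxicity, read by microscopy; a higher number here means that more compound is tolerated, a lower number that less compound is tolerated. Compound 2 `COc1cc(CC(O)c2ccc(-c3ccc(Br)cc3)cc2)c([N+](=O)[O-])cc1OC` gives 4300 nM in this assay, and compound 3 `COc1cc(CC(O)c2ccc(-c3cccc(Cl)c3)cc2)c([N+](=O)[O-])cc1OC` gives 5900 nM. Compound 3 carries the largest of the three numbers, but its distance to the others is small: a 1.3-fold higher number from compound 1 to compound 3 (0.10 log units; within the scatter) and a 1.4-fold higher number from compound 2 to compound 3 (0.14 log units; within the scatter), so all three are indistinguishable at the level of the measurement.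

Compound 4 `COc1cc(CC(O)c2ccc(-c3ccccc3C#N)cc2)c([N+](=O)[O-])cc1OC` takes the next step from compound 3: 2-cyanophenyl in place of 3-chlorophenyl on an aromatic carbon. The steps already measured that bear on this change are those that alter the same outer ring, namely a 1.1-fold lower number from compound 1 to compound 2 (0.04 log units; within the scatter), a 1.3-fold higher number from compound 1 to compound 3 (0.10 log units; within the scatter) and a 1.4-fold higher number from compound 2 to compound 3 (0.14 log units; within the scatter). Each of them stayed within the scatter, whether the substituent was methyl, bromo or chloro and wherever on that ring it sat. On that basis no step beyond the scatter is expected for compound 4 in this assay in either direction. Compound 4 is therefore estimated at 5500 nM, with a range of 2700 nM to 11000 nM, which means an expected step of a 1.1-fold lower number from compound 3 to compound 4 (0.03 log units; within the scatter).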

Compound 4, half-maximal cytotoxic concentration: 9300 nM
Compound 4: middle estimate off by 1.7-fold (0.23 log units), on the low side, within the range that was stated.
By their numbers in this assay, from the lowest: compounds 2, 1, 3 and 4 (each within the scatter of the next, the first and the last beyond it).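

In this assay, for the compounds shown here, the 2-cyanophenyl ring gives the only step in this outer-ring series that leaves the scatter, and it does so against one neighbour alone: there is a 2.2-fold higher number from compound 2 to compound 4 (0.34 log units; beyond the scatter) and this step is modest, while a 2.0-fold higher number from compound 1 to compound 4 (0.30 log units; within the scatter) and a 1.6-fold higher number from compound 3 to compound 4 (0.20 log units; within the scatter) both stay inside the scatter. The methyl, bromo and chloro rings had suggested that this aromatic carbon takes any such swap without a readable change, whereas the nitrile shows that a ring replacement here can separate two compounds, though only at the edge of what the measurement can tell. Nothing at hand says what lies behind this step.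

The compounds shown leave open whether the nitrile itself or its place on the ring accounts for the step, since compound 4 differs from compounds 1, 2 and 3 in both at once. They also leave open whether an amine or a carboxylic acid on this outer ring would give a clearer step than the nitrile in this assay or none at all.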